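From Methoxy to Fluoro: Expecting Little Change

The source may report more compounds than this note shows. Statements on the series, on what has been measured and on what is new or still open speak of the compounds shown alone.

Of the compounds shown here, three have already been tested in a functional assay on Mahlavu cells (Homo sapiens) for inhibition, read by sulforhodamine B assay, with a stated time of 72 h; on this read-out higher numbers stand for weaker inhibition and lower numbers for stronger inhibition. Compound 1 `CC(c1ccc(-c2ccccc2)c(F)c1)c1n[nH]c(=S)n1N` is reported in this assay as "not active" (no number reported). Compound 3 `COc1ccc2cc(C(C)c3n[nH]c(=S)n3N)ccc2c1` is reported in this assay as "not active" (no number reported). Among the measured compounds shown here, compound 2 `COc1ccc(C2=Nn3c(nnc3C(C)c3ccc(-c4ccccc4)c(F)c3)SC2)cc1` gives 5800 nM in this assay, which makes it the only compound with a number; the other two entries carry no number at all, so nothing can be said about how far apart the three stand.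

Compound 4 `CC(c1ccc(-c2ccccc2)c(F)c1)c1nnc2n1N=C(c1ccc(F)cc1)CS2` keeps everything in compound 2 except one group: the change is fluoro in place of methoxy on an aromatic carbon. For the measured compounds named here, no pair of measured compounds shows this swap, so there is no measured step to learn its size from. A change this small, far from the rest of the molecule, is expected to move the value little, if at all. The step from compound 2 to compound 4 is estimated as a 1.1-fold higher number from compound 2 to compound 4 (0.05 log units; within the scatter), a shift that stays within the usual scatter. Compound 4 is therefore expected to land near 6500 nM, with a plausible range from 2500 nM to 16000 nM; given that two of the three measured entries returned no number, there is a real chance that compound 4 also comes back without one.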

Compound 4, half-maximal inhibitory concentration: 7400 nM
Beside the measured number, compound 4's estimate is 1.1-fold (0.06 log units) below it; the range from low to high includes it.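

Among the compounds shown here, replacing the 4-methoxyphenyl with a 4-fluorophenyl gives the first measured step at this position: in this assay the swap reads as a 1.3-fold higher number from compound 2 to compound 4 (0.11 log units; within the scatter) and so the two values cannot be told apart. This adds something the earlier entries could not offer, since a number on each side of a single change lets this position be judged directly rather than assumed. On this shared core, the methoxy, with two heavy atoms and one hydrogen-bond acceptor, and the fluoro, with one heavy atom and no acceptor, leave the read-out in the same place, so neither that extra heavy atom nor that acceptor registers in this pair. No independent measurement is available to explain why the two groups read alike.

Going by these compounds, only these two groups have been seen at this position, so it stays open whether an amine, a carboxylic acid or a longer chain such as butoxy on the same ring would keep the value in this range or lose it altogether. A single pair is also no pattern, and whether the same swap would read alike on another core cannot be said from these compounds.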